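Polar amide substituents on a dilauroyl thioether lipopeptide

The source may report more compounds than this note shows. Statements on the series, on what has been measured and on what is new or still open speak of the compounds shown alone.

Going by the values given here, compound 3 `CCCCCCCCCCCC(=O)OC[C@H](CSC[C@@H](N)C(=O)NC(CC)COC)OC(=O)CCCCCCCCCCC` gives the highest of the three numbers so far in an assay on HEK293 cells for agonist activity at Toll-like receptor 2 (Homo sapiens) (on this read-out higher numbers stand for an effect only at larger amounts of compound and lower numbers for an effect already at smaller amounts), at 71.8 nM. Compound 1 `CCCCCCCCCCCC(=O)OC[C@H](CSC[C@@H](N)C(=O)NCCCCCCO)OC(=O)CCCCCCCCCCC` gives 33 nM in this assay, and compound 2 `CCCCCCCCCCCC(=O)OC[C@H](CSC[C@@H](N)C(=O)NCCOCCOS(=O)(=O)O)OC(=O)CCCCCCCCCCC` gives 61 nM. Among these, a 2.2-fold higher number from compound 1 to compound 3 (0.34 log units; beyond the scatter), whereas a 1.2-fold higher number from compound 2 to compound 3 (0.07 log units; within the scatter) and a 1.8-fold higher number from compound 1 to compound 2 (0.27 log units; within the scatter).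

Compound 4 `CCCCCCCCCCCC(=O)OC[C@H](CSC[C@@H](N)C(=O)N[C@@H](CC)COCC(=O)O)OC(=O)CCCCCCCCCCC` differs from compound 3 only at the amide-type nitrogen: 1-((carboxymethoxy)methyl)propyl in place of 1-(methoxymethyl)propyl on an amide-type nitrogen. The measured steps that bear on this are those which replaced the 6-hydroxyhexyl or the 2-(2-(sulfooxy)ethoxy)ethyl chain with the 1-(methoxymethyl)propyl group; both were small, and the hydroxyl-to-sulfooxy exchange from compound 1 to compound 2 was also within the scatter. The new substituent again carries a chain ending in a charged-capable oxygen function, so a small step is expected for compound 4, a 1.3-fold lower number from compound 3 to compound 4 (0.12 log units; within the scatter), pointing toward a somewhat lower number because compound 2 gives 61 nM with its 2-(2-(sulfooxy)ethoxy)ethyl chain. Compound 4 is thus estimated at 55 nM, with a range from 25 nM to 130 nM.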

Compound 4, half-maximal effective concentration: 6500 nM
The estimate for compound 4 lay 120-fold (2.07 log units) below the measured number; the measured number lies above the stated range.
By their numbers in this assay, from the lowest: compounds 1, 2 and 3 (each within the scatter of the next, the first and the last beyond it); then compound 4.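

At this amide-type nitrogen, the earlier exchanges moved the number only slightly in this assay, but the 1-((carboxymethoxy)methyl)propyl group produces a large loss (a 91-fold higher number from compound 3 to compound 4 (1.96 log units; beyond the scatter)). A chain ending in an oxygen-bearing acid group is therefore not interchangeable here: the 2-(2-(sulfooxy)ethoxy)ethyl chain of compound 2 stands far apart from this group (a 110-fold higher number from compound 2 to compound 4 (2.03 log units; beyond the scatter)), and the gap to the 6-hydroxyhexyl chain of compound 1 is also large (a 200-fold higher number from compound 1 to compound 4 (2.29 log units; beyond the scatter)). Nothing available explains the size of this jump.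

As far as these compounds go, it remains open whether the loss follows the carboxylic acid itself or the longer substituent, a question that the methyl ester or primary amide at the same chain end would address. From the compounds shown here alone, the opposite configuration at the defined stereocentre of compound 4 also remains open.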